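Replacing the 5-hydroxy-2-oxopiperidin-1-yl group of compound 3

This account rests on a few compounds, and the source may have more. Where it says the series, first, only, none or still open, it means among the compounds named here.

- compound 1 (`CC(C)c1noc(N2CCC(Oc3cc(N4CCc5cc(N6CCCCC6=O)ccc54)ncn3)CC2)n1`): 3.8
- compound 2 (`CC(C)c1noc(N2CCC(Oc3cc(N4CCc5cc(C6CCCCC6=O)ccc54)ncn3)CC2)n1`): 4.7
- compound 3 (`CC(C)c1noc(N2CCC(Oc3cc(N4CCc5cc(N6CC(O)CCC6=O)ccc54)ncn3)CC2)n1`): 2.6

In a physicochemical assay for lipophilicity, measured as octanol-water partition, at pH 7.4 (on this read-out lower numbers stand for lower lipophilicity and higher numbers for higher lipophilicity), compound 3 stands lowest of the three measured compounds. Compound 4 (`CC(C)c1noc(N2CCC(Oc3cc(N4CCc5cc(N6CCCS6(=O)=O)ccc54)ncn3)CC2)n1`) has not yet been measured. The change that leads to it is a group of 7 heavy atoms (3 carbon, 1 nitrogen, 2 oxygen, 1 sulfur; one five-membered non-aromatic ring with 2 hetero atoms) in place of a group of 8 heavy atoms (5 carbon, 1 nitrogen, 2 oxygen; one six-membered non-aromatic ring with 1 hetero atom), on an aromatic carbon and it sits para to a fused ring. For the measured compounds named here, no measured compound carries the entering ring, so the evidence is indirect. Two steps at this same place bear on it: a number 0.90 log units higher from compound 1 to compound 2 (beyond the scatter) and a number 2.10 log units lower from compound 2 to compound 3 (beyond the scatter) show that the read-out moves widely with the group there. The closest guide is hydroxy in place of hydrogen on a saturated ring carbon, which gave a number 1.20 log units lower from compound 1 to compound 3 (beyond the scatter) and left compound 3 at the bottom. The entering group has no hydroxy, so compound 4 is expected to lie nearer compound 1, though probably somewhat under it. A modest rise is therefore expected, and the estimated step is a number 0.80 log units higher from compound 3 to compound 4 (beyond the scatter) in this direction. Compound 4 is estimated at 3.4 (expected range 2.9 to 3.9).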

Compound 4, distribution coefficient: 3.2
Compound 4: middle estimate off by 0.20 log units, on the high side; the measured number falls inside the stated range.
By their numbers in this assay, from the lowest: compound 3; then compound 4; then compound 1; then compound 2.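

In this assay, a group without a hydroxy need not return to the level of the six-membered lactam of compound 1: the five-membered ring containing sulfur gives a number 0.60 log units higher from compound 3 to compound 4 (beyond the scatter) but also a number 0.60 log units lower from compound 1 to compound 4 (beyond the scatter), placing compound 4 between the two nitrogen-linked six-membered rings. It remains far from the carbon-linked ketone ring, with a number 1.50 log units lower from compound 2 to compound 4 (beyond the scatter), so this position now shows an intermediate level reached by a ring of a different size and atom make-up. No measurement here offers an explanation for this placing.

The entering group differs from the others in ring size and in its sulfur at once, so the compounds shown do not separate these two changes. A six-membered ring with the same sulfur would address that, while an open-chain sulfonamide would test whether the ring itself matters.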